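Amide nitrogen methylation and microsomal clearance in the series

This account rests on a few compounds, and the source may have more. Where it says the series, first, only, none or still open, it means among the compounds named here.

Measured compounds and values:
Compound 1, `CN(C(=O)c1ccccc1)c1cnc(NCc2c(F)ccc3c2CCO3)n2cnnc12`, gives in an ADME assay on microsomes from liver (Homo sapiens) for metabolic stability, read by LC-MS, using NADPH, with stated times of 5 min and 30 min, tested at 1 uM (a lower number here means slower removal, a higher number faster removal of the compound), only a limit of the assay, > 300 mL.min-1.g-1.
Compound 2, `O=C(Nc1cnc(NCc2c(F)ccc3c2CCO3)n2cnnc12)c1ccccc1`, gives in this assay 10 mL.min-1.g-1.
Compound 3, `CNC(=O)c1ccc(-c2cnc(NCc3c(F)ccc4c3CCO4)c3cn[nH]c(=O)c23)c(C)n1`, gives in this assay 23 mL.min-1.g-1.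

Compound 4, `Cc1nc(C(=O)N(C)C)ccc1-c1cnc(NCc2c(F)ccc3c2CCO3)c2cn[nH]c(=O)c12`, has not yet been measured in this assay.

Between compound 2 and compound 1 the change is methyl in place of hydrogen on an amide-type nitrogen. The step is an at least 30-fold higher number from compound 2 to compound 1 (1.47 log units; beyond the scatter); the value of compound 1 is a limit of the assay, as the limit of > 300 mL.min-1.g-1 in this assay, at which 1 of the 3 values shown sits, records, so the true size of that step is not known beyond that. Compound 3 carries a different core; the difference between the core of compound 2 and the core of compound 3 is not broken down here. Compound 3 stands higher than compound 2 in this assay.

From compound 3 to compound 4 the change is methyl in place of hydrogen on an amide-type nitrogen. It is the same kind of change as from compound 2 to compound 1, but not the same: in compound 1 the amide-type nitrogen has an aromatic carbon and a carbonyl carbon as other neighbours, in compound 4 a carbonyl carbon and a saturated chain carbon. The expectation for compound 4 therefore rests on compound 2 and compound 1, through an at least 30-fold higher number from compound 2 to compound 1 (1.47 log units; beyond the scatter), read with the difference in surroundings in mind. The step from compound 3 to compound 4 is expected to be a 2.6-fold higher number from compound 3 to compound 4 (0.42 log units; beyond the scatter), an increase, but with no basis for expecting it to reach the size seen from compound 2 to compound 1. Compound 4 is estimated at 60 mL.min-1.g-1, with a range from 25 mL.min-1.g-1 to 150 mL.min-1.g-1.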

Compound 4, intrinsic clearance in microsomes in the Homo sapiens assay: 19 mL.min-1.g-1
The estimate for compound 4 lay 3.2-fold (0.50 log units) above the measured number, and the stated range ends above it.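

In the Homo sapiens assay, methyl in place of hydrogen on the amide-type nitrogen gives a 1.2-fold lower number from compound 3 to compound 4 (0.08 log units; within the scatter), and this step differs from the one on the other core: the same change on two cores in the Homo sapiens assay, an at least 30-fold higher number (1.47 log units; beyond the scatter) from compound 2 to compound 1 and a 1.2-fold lower number (0.08 log units; within the scatter) from compound 3 to compound 4, at least 36-fold (1.56 log units) apart, beyond the scatter of two such steps The large step seen with compound 2 and compound 1 therefore does not carry over to the pair compound 3 and compound 4, and the change cannot be treated as having one size across this series; the earlier step also has no known upper end, as compound 1 sits at a limit of the assay: the limit of > 300 mL.min-1.g-1 in the Homo sapiens assay, at which 1 of the 4 values shown sits. What is not shown is whether the core or the other neighbours of the nitrogen (an aromatic carbon and a carbonyl carbon in compound 1, a carbonyl carbon and a saturated chain carbon in compound 4) account for the gap, since each step rests on a single pair and both features differ at once.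

In a physicochemical assay for solubility, read by LC-MS, in phosphate buffer, with a stated time of 24 h, at pH 7.4 (a higher number here means a more soluble compound, a lower number a less soluble compound), compound 3 gives 19000 nM and compound 4 gives 403000 nM. Open, going by these compounds, is whether the higher number in the physicochemical assay, so far seen on one pair, also holds on the core of compound 2: the measured solubility of compound 3, 19000 nM, and of compound 4, 403000 nM, a 21-fold higher number (1.33 log units; beyond the scatter) Also open is how an ethyl group on that nitrogen, or a pyrrolidine amide in place of the dimethylcarbamoyl, would read in the Homo sapiens assay on the core of compound 3.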